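The source may report more compounds than this note shows. Statements on the series, on what has been measured and on what is new or still open speak of the compounds shown alone.

In an assay on HEK293 cells for positive allosteric modulation of metabotropic glutamate receptor 5 (Homo sapiens), read by FLIPR (a higher number here means that more compound is needed for the effect, a lower number that less compound is needed), three compounds have been measured so far:

Compound 1 `O=C(N1CCCCC1)N1CC(c2nc(-c3cccc(Cl)c3)no2)C1` gives 370 nM.
Compound 3 `O=C(C1CCC(F)(F)CC1)N1CC(c2nc(-c3cccc(Cl)c3)no2)C1` gives 180 nM.
Compound 2 `CC1CCN(C(=O)N2CC(c3nc(-c4cccc(Cl)c4)no3)C2)C1` gives only a limit of this assay, > 10000 nM.

Compound 3 therefore holds the lowest number shown; the nearest is compound 1, with a 2.1-fold lower number from compound 1 to compound 3 (0.31 log units; beyond the scatter). Compound 4 `CC1CN(C(=O)N2CC(c3nc(-c4cccc(Cl)c4)no3)C2)CC(C)O1` differs from compound 3 in one place: 2,6-dimethylmorpholin-4-yl in place of 4,4-difluorocyclohexyl on a carbonyl carbon. Within the data shown here, two measured steps bear on this. Swapping the 4,4-difluorocyclohexyl for an unsubstituted ring nitrogen cost only a modest amount, as the step from compound 3 back to compound 1 shows, whereas an at least 55-fold lower number from compound 2 to compound 3 (1.74 log units; beyond the scatter) shows that a methyl-bearing ring nitrogen on that carbonyl carbon can cost a great deal. Compound 4 carries two methyls, and the step expected from this change is estimated as an 8.3-fold higher number from compound 3 to compound 4 (0.92 log units; beyond the scatter), of uncertain exact size. Compound 4 is estimated at 1500 nM, between 300 nM and 10000 nM.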

Compound 4, half-maximal effective concentration: > 10000 nM
Compound 4 was reported as a limit; the forecaster's own chance of this, stated with the estimate: 25%; at least 6.6-fold (0.82 log units) between middle value and limit.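

In this assay, 2,6-dimethylmorpholin-4-yl on this carbonyl carbon brings an at least 55-fold higher number from compound 3 to compound 4 (1.74 log units; beyond the scatter), and it also brings an at least 27-fold higher number from compound 1 to compound 4 (1.43 log units; beyond the scatter). A six-membered ring here is therefore not enough on its own to keep the effect, since compound 1 and compound 3 keep it and compound 4 does not. The step between compound 2 and compound 4 cannot be read, and both values are limits: the limit of > 10000 nM in this assay, at which 2 of the 4 values shown sit.

Whether the two methyls or the ring oxygen of compound 4 account for the loss stays open. An unsubstituted morpholin-4-yl or a 2,6-dimethylpiperidin-1-yl on this carbonyl carbon would separate the two.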